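The source may report more compounds than this note shows. Statements on the series, on what has been measured and on what is new or still open speak of the compounds shown alone.

Of the compounds shown here, two have been measured in an assay on isolated protein for binding affinity to Gonadotropin-releasing hormone receptor (Homo sapiens); on this read-out lower numbers stand for stronger inhibition and higher numbers for weaker inhibition. Compound 1 `CCOC(=O)[C@H]1CC[C@H](CNC(=O)c2ccc(Cc3cc4c(cc3C)C(C)(C)CCC4(C)C)o2)CC1` gives 51 nM in this assay. Compound 2 `Cc1cc2c(cc1Cc1ccc(C(=O)NCC3CCC(CNCc4c(C)noc4C)CC3)o1)C(C)(C)CCC2(C)C` gives 180 nM in this assay. Compound 1 stands lowest of the two numbers, and the gap to compound 2 lies beyond the usual scatter. Compound 3 `Cc1cc2c(cc1Cc1ccc(C(=O)NCC3CCCC(CN)C3)o1)C(C)(C)CCC2(C)C` has not yet been measured. It is reached from compound 1 by the change 3-(aminomethyl)cyclohexyl in place of 4-(ethoxycarbonyl)cyclohexyl on a saturated chain carbon bound to an amide-type nitrogen: the ethoxycarbonyl group leaves and an aminomethyl group enters on the cyclohexyl ring. Among the measured compounds shown here, no step between measured compounds covers this change, so the expectation rests on the two numbers alone. Compound 2, which also carries an amine in its chain, gives 180 nM, a higher number than compound 1, and a move of similar kind is expected here. Compound 3 is expected to give 150 nM in this assay, within 50 nM to 450 nM. The expected step of a 2.9-fold higher number from compound 1 to compound 3 (0.47 log units; beyond the scatter) thus points toward weaker binding.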

Compound 3, inhibition constant: 174 nM
The estimate for compound 3 lay 1.2-fold (0.06 log units) below the measured number; the range from low to high includes it.
By their numbers in this assay, from the lowest: compound 1; then compounds 3 and 2 (each within the scatter of the next).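

In this assay, among the compounds shown here, 3-(aminomethyl)cyclohexyl in place of 4-(ethoxycarbonyl)cyclohexyl on a saturated chain carbon bound to an amide-type nitrogen gives a 3.4-fold higher number from compound 1 to compound 3 (0.53 log units; beyond the scatter), the only step so far that can be read at this position. The position accepts an exchange of the whole cyclohexyl substituent without loss of measurable binding, since compound 3 still gives 174 nM, although the number rises beyond the scatter. The step combines the loss of ethoxycarbonyl, the entry of aminomethyl and the shift from a 4- to a 3-substituted cyclohexyl, and no supporting measurement bears on the reason for the rise.

From the compounds shown here alone, how much of the step belongs to the group and how much to its place on the ring stays open. A 4-(aminomethyl)cyclohexyl group or a 4-carboxycyclohexyl group at this position would help to separate these contributions.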